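Replacing a 3-cyanophenyl amide with cyclopropyl

The compounds below may be only part of what the source reports. "The series", "measured", "known", "first", "only" and "open" are said of these compounds alone.

Measured compounds:
- compound 1 `O=C(Nc1ccccc1O)c1cccc(N2C(=O)c3ccccc3C2=O)c1`: 77 nM
- compound 2 `COc1ccccc1C(=O)Nc1cccc(NC(=O)c2cc(Cl)cc(Cl)c2)c1`: a limit, > 30000 nM
- compound 3 `COc1ccccc1C(=O)Nc1cccc(NC(=O)c2cccc(C#N)c2)c1`: 1800 nM

In an in vitro functional assay on HEK293-A cells for antagonist activity at metabotropic glutamate receptor 5 (Rattus norvegicus), read by calcium flux (on this read-out higher numbers stand for weaker inhibition and lower numbers for stronger inhibition), compound 1 gives 77 nM. Compound 2 reaches only the limit of this assay, > 30000 nM; this is the line (the limit of > 30000 nM in this assay, at which 1 of the 3 values shown sits). Compound 3 gives 1800 nM and so stands highest of the two numbers shown, with compound 1 the nearest, a substantially lower number. Within the data shown here, the one measured step on the same carbonyl carbon, an at least 16-fold lower number from compound 2 to compound 3 (1.22 log units; beyond the scatter), shows that the group there moves the number by a large amount.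

Compound 4 `COc1ccccc1C(=O)Nc1cccc(NC(=O)C2CC2)c1` is not yet measured. It differs from compound 3 in one place: cyclopropyl in place of 3-cyanophenyl on a carbonyl carbon. Among the measured compounds shown here, only the step from compound 2 to compound 3 bears on this position, and it shows a large swing for an aryl-to-aryl swap; a far smaller group now enters. The change from compound 3 to compound 4 is therefore expected to raise the number, with the step of a 4.4-fold higher number from compound 3 to compound 4 (0.65 log units; beyond the scatter). Compound 4 is estimated at 8000 nM, within a range from 1500 nM to 30000 nM, and it may reach the limit of this assay.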

Compound 4, half-maximal inhibitory concentration: > 30000 nM
Compound 4: only a limit was reported; the forecaster's own chance of this, stated with the estimate: 35%; middle value at least 3.7-fold (0.57 log units) from the limit.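

The step of an at least 16-fold higher number from compound 3 to compound 4 (1.22 log units; beyond the scatter) shows that, on this carbonyl carbon, the change from an aromatic 3-cyanophenyl to the non-aromatic cyclopropyl is not tolerated in this assay, and the value of compound 4 is a limit, not a number. The earlier compounds had shown only that one aryl group could differ widely from another; now, of the three groups shown at this place, 3-cyanophenyl alone gives a number inside the range of the read-out, while 3,5-dichlorophenyl and cyclopropyl both end at the limit: the limit of > 30000 nM in this assay, at which 2 of the 4 values shown sit. The step between compound 2 and compound 4 cannot be read, so these two groups cannot be put in order.

With only one readable value at this position, the compounds shown leave open whether the nitrile, the aromatic ring or the two together go with the inhibition seen for compound 3. An unsubstituted phenyl group on the same carbonyl carbon would begin to separate these, and a 3-pyridyl group or a 3-methoxyphenyl group would show whether anything other than the nitrile can stand in its place.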